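Trading Chloro for Hydrogen on the Core of Compound 3

The source may hold more compounds than are shown below. What is called first, only, known or untested is meant among the compounds shown, and "the series" means these compounds.

Three compounds share a fused two-ring core. Compound 1 `Nc1nc(Cl)c2ncn(Cc3ccccc3CCl)c2n1` carries an amino group on the six-membered ring, and in a functional assay on SK-MEL-5 cells (Homo sapiens) for cytotoxicity, read by sulforhodamine B assay, with a stated time of 48 h (a lower number here means that less compound is tolerated, a higher number that more compound is tolerated), compound 1 gives 75900 nM. Compound 2 `ClCc1ccc(Cn2cnc3c(Cl)nc(Cl)nc32)cc1` carries two chloro groups and gives 44700 nM. Compound 3 `ClCc1ccccc1Cn1cnc2c(Cl)nc(Cl)nc21` gives 4260 nM, the lowest of the three numbers: compound 2 stands well above it, and the step of an 18-fold lower number from compound 1 to compound 3 (1.25 log units; beyond the scatter) is large, so compound 3 is the least tolerated of the set.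

Compound 4 `ClCc1ccccc1Cn1cnc2c(Cl)ncnc21` differs from compound 3 at a single place: hydrogen in place of chloro on an aromatic carbon. Going by the values given here, the one measured step at that place is an 18-fold lower number from compound 1 to compound 3 (1.25 log units; beyond the scatter), where chloro replaced amino and the number fell steeply. Compound 4 moves away from chloro again, but toward hydrogen rather than amino, so a rise smaller than that step is expected. Compound 4 is therefore expected to give 12000 nM, with a range from 3000 nM to 50000 nM, an expected step of a 2.8-fold higher number from compound 3 to compound 4 (0.45 log units; beyond the scatter).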

Compound 4, concentration lethal to 50% of the cells: 5880 nM
Compound 4: middle estimate off by 2.0-fold (0.31 log units), on the high side; the measured number falls inside the stated range.
By their numbers in this assay, from the lowest: compounds 3 and 4 (each within the scatter of the next); then compounds 2 and 1 (each within the scatter of the next).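

In this assay, hydrogen in place of chloro on this aromatic carbon gives a 1.4-fold higher number from compound 3 to compound 4 (0.14 log units; within the scatter) and so leaves no readable difference between the two groups at this position. Hydrogen in place of amino, by contrast, gives a 13-fold lower number from compound 1 to compound 4 (1.11 log units; beyond the scatter) and is large, so the low number of compound 3 does not depend on having chloro here; of the three groups tried at this carbon, amino is the one that stands apart. No measurement at hand accounts for this difference.

The compounds shown leave open whether a methoxy group or a methylamino group at this carbon would read like amino or like hydrogen. They also leave open whether hydrogen in place of chloro would read the same way on compound 2, whose benzyl substituent differs from that of compound 3.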